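Working notes: from compound 2 to compound 3

This account rests on a few compounds, and the source may have more. Where it says the series, first, only, none or still open, it means among the compounds named here.

Measured so far in a functional assay on A549 cells (Homo sapiens) for cytotoxicity, read by MTT assay; a higher number here means a weaker inhibitor, a lower number a stronger inhibitor:
- compound 1 `COc1ccc(OC)c(C(=O)/C=C/c2cccs2)c1`: 11000 nM
- compound 2 `COc1ccc(OC)c(C(=O)/C=C/c2ccc(OC(=O)/C=C/c3ccc(C)cc3)cc2)c1`: 29700 nM

Compound 2 stands at 29700 nM in this assay. This is the higher of the two numbers, so it marks the weaker inhibitor of the pair, and the gap to compound 1 lies beyond the scatter.

The next compound is compound 3 `COc1ccc(OC)c(C(=O)/C=C/c2ccc(OC(=O)/C=C/c3cc(OC)c(OC)c(OC)c3)cc2)c1`, which has not yet been measured. It differs from compound 2 by one change, (3,4,5-trimethoxyphenyl in place of 4-methylphenyl on a double-bonded chain carbon bound to a double-bonded chain carbon), with 3,4,5-trimethoxyphenyl in place of 4-methylphenyl on a double-bonded chain carbon bound to a double-bonded chain carbon.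

Among the compounds with values here, no measured pair differs in one place, so the data give no direct precedent for this change. Within the data shown here, the only guide is the span of the two values, with compound 1 at 11000 nM and compound 2 at 29700 nM. In this assay a small shift toward a lower number is expected, not clearly beyond the scatter. The expected change is a 1.7-fold lower number from compound 2 to compound 3 (0.22 log units; within the scatter) and remains uncertain in both size and direction. For compound 3 the estimated value is 18000 nM with an expected range from 6000 nM to 45000 nM overall.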

Compound 3, half-maximal inhibitory concentration: 36700 nM
Compound 3: the middle estimate sits 2.0-fold (0.31 log units) below what was measured; the measured number falls inside the stated range.
By their numbers in this assay, from the lowest: compound 1; then compounds 2 and 3 (each within the scatter of the next).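

In this assay the series now has its first comparison of compounds that differ in one place: 3,4,5-trimethoxyphenyl in place of 4-methylphenyl on a double-bonded chain carbon bound to a double-bonded chain carbon gives a 1.2-fold higher number from compound 2 to compound 3 (0.09 log units; within the scatter). This place therefore accepts a group of 12 heavy atoms with 3 hydrogen-bond acceptors in place of one of 7 heavy atoms with none, and the two readings cannot be told apart in this assay. No measurement is available that could explain this agreement.

From the compounds shown here alone, both groups compared here carry a six-membered aromatic ring of carbon only, no net charge and no hydrogen-bond donors, so it remains open how a group bearing an amine or a carboxylic acid would read at this place. Also open, going by these compounds, is whether a phenyl ring with a single methoxy group, or a longer chain in place of the ring, would give a reading distinct from those of compound 2 and compound 3.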